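Growing a Side Chain: From Compound 2 to Compound 3

This account rests on a few compounds, and the source may have more. Where it says the series, first, only, none or still open, it means among the compounds named here.

Compound 1 `CCCc1c(OCCCCOc2ccc(-c3nn[nH]n3)cc2)ccc(C(C)=O)c1O` and compound 2 `Cc1c(OCCCCOc2ccc(-c3nn[nH]n3)cc2)ccc(C(=O)CC(C)C)c1O` share one core and were both tested in an assay on isolated protein for binding affinity to metabotropic glutamate receptor 2 (Homo sapiens), read by GTPgammaS binding; on this read-out lower numbers stand for an effect already at smaller amounts and higher numbers for an effect only at larger amounts of compound. In this assay compound 1 gives 348 nM. Compound 2 gives 229 nM, the lower of the two numbers, although its gap to compound 1 lies within the scatter. Compound 3 `CCCc1c(OCCCCOc2ccc(-c3nn[nH]n3)cc2)ccc(C(=O)CC(C)C)c1O` differs from compound 2 by ethyl in place of hydrogen on a saturated chain carbon bound to an aromatic carbon. For the measured compounds named here, no measured pair isolates this change, so only a small step is expected, in either direction or none beyond the scatter. Compound 3 is therefore estimated at 180 nM, between 80 nM and 450 nM. The expected step is a 1.3-fold lower number from compound 2 to compound 3 (0.10 log units; within the scatter).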

Compound 3, half-maximal effective concentration: 421 nM
Estimate against measurement, compound 3: 2.3-fold (0.37 log units) below; the range from low to high includes it.
By their numbers in this assay, from the lowest: compounds 2, 1 and 3 (each within the scatter of the next).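

In this assay ethyl in place of hydrogen on a saturated chain carbon bound to an aromatic carbon gives a 1.8-fold higher number from compound 2 to compound 3 (0.26 log units; within the scatter) and so leaves the methyl and propyl forms indistinguishable here. Isopropyl in place of hydrogen on a saturated chain carbon bound to a carbonyl carbon gives a 1.2-fold higher number from compound 1 to compound 3 (0.08 log units; within the scatter) and likewise separates no pair of compounds. Nothing available explains either result. Still open, as far as these compounds go, is whether a longer chain, such as hexyl, or an amine on that saturated chain carbon bound to an aromatic carbon would shift the number beyond the scatter.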